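The source may report more compounds than this note shows. Statements on the series, on what has been measured and on what is new or still open speak of the compounds shown alone.

Of the compounds shown here, three sharing one core have been measured in an assay on CHO cells for displacement of a labelled ligand from Substance-P receptor (Homo sapiens); a lower number here means a stronger inhibitor, a higher number a weaker inhibitor. Compound 1 `CC(C)C(=O)N1C[C@@H](O[C@H](C)c2cc(C(F)(F)F)cc(C(F)(F)F)c2)[C@H](c2ccc(F)cc2)C1` gives 0.15 nM. Compound 2 `C[C@@H](O[C@@H]1CN(C(=O)C(C)(C)C)C[C@H]1c1ccccc1)c1cc(C(F)(F)F)cc(C(F)(F)F)c1` gives 0.18 nM, and compound 3 `C[C@@H](O[C@@H]1CN(C(=O)[C@@H]2CCC(=O)N2C)C[C@H]1c1ccc(F)cc1)c1cc(C(F)(F)F)cc(C(F)(F)F)c1` gives 0.12 nM. Compound 1 sits in the middle of these three numbers; its gaps to compound 2 and to compound 3 both lie within the scatter, so the three cannot be told apart.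

The new compound 4 `Cc1cnc(C(=O)N2C[C@@H](O[C@H](C)c3cc(C(F)(F)F)cc(C(F)(F)F)c3)[C@H](c3ccc(F)cc3)C2)cn1` is compound 1 with one change: 5-methylpyrazin-2-yl in place of isopropyl on a carbonyl carbon. Among the compounds with values here, one measured step bears on this. Going a 1.3-fold lower number from compound 1 to compound 3 (0.10 log units; within the scatter), the isopropyl on the carbonyl carbon was likewise replaced by a ring-bearing group, and the number hardly moved. On that basis a change at the same carbonyl carbon is expected to leave the number where it is, with no step beyond the scatter in either direction, which is what a 1.3-fold higher number from compound 1 to compound 4 (0.12 log units; within the scatter) expresses. Compound 4 is therefore estimated at 0.2 nM, within a range from 0.07 nM to 0.6 nM in this assay.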

Compound 4, half-maximal inhibitory concentration: 0.12 nM
For compound 4 the middle estimate is 1.7-fold (0.22 log units) above the measured one; the measured number falls inside the stated range.
By their numbers in this assay, from the lowest: compounds 3, 4, 1 and 2 (each within the scatter of the next).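

In this assay, within the data shown here, the replacement of isopropyl by 5-methylpyrazin-2-yl on the carbonyl carbon gives a 1.3-fold lower number from compound 1 to compound 4 (0.10 log units; within the scatter), so this position also takes a six-membered aromatic ring with 2 hetero atoms, a kind of group the earlier compounds did not carry there. Exchanging 1-methyl-5-oxopyrrolidin-2-yl for 5-methylpyrazin-2-yl gives no change at the digits printed from compound 3 to compound 4 (within the scatter), so the three groups seen on this carbonyl carbon in compounds 1, 3 and 4 cannot be told apart in this measurement, although they differ in size and ring type. Nothing available explains why these different groups give such similar numbers.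

On these data alone, none of these three groups moves the number beyond the scatter, so the limits of what this position accepts remain unknown. As far as these compounds go, it stays open how an amine, a carboxylic acid or a longer chain on the same carbonyl carbon would compare.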